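The compounds below may be only part of what the source reports. "The series", "measured", "known", "first", "only" and "open" are said of these compounds alone.

Of the compounds shown here, three have been measured in an assay on cells for inhibition of sodium- and chloride-dependent glycine transporter 1 (Homo sapiens); a lower number here means that less compound is needed, a higher number that more compound is needed for the effect. Compound 1 `COc1cc(C(F)(F)F)cc(C(F)(F)F)c1C(=O)NC1(c2ccccc2)CCCN(CC2CC2)C1` gives 380 nM. Compound 2 `COc1cc(C(F)(F)F)cc(C(F)(F)F)c1C(=O)NC1(c2ccccc2)CCCN(Cc2ccccc2)C1` gives 6700 nM; the step of an 18-fold higher number from compound 1 to compound 2 (1.25 log units; beyond the scatter) is the only step measured between two of these compounds. Compound 3 `COc1cc(C(F)(F)F)ccc1C(=O)NC1(c2ccccc2)CCCN(C)C1` gives 4800 nM. Its number and that of compound 2 lie within the scatter of each other, while compound 1 needs clearly less compound than compound 3, the two values standing apart by more than the scatter.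

Compound 4 `CN1CCCC(NC(=O)c2ccc(C(F)(F)F)cc2C(F)(F)F)(c2ccccc2)C1` differs from compound 3 in one place: trifluoromethyl in place of methoxy on an aromatic carbon. For the measured compounds named here, no measured step touches this part of the structure; the one measured step, between compound 1 and compound 2, concerns the group on the saturated chain carbon bound to the amine nitrogen in the ring, not the aromatic carbon where compound 3 and compound 4 differ. The measured data therefore give no basis to expect a shift beyond the scatter in this assay. The expected value for compound 4 is thus 4800 nM, with a range from 1500 nM to 15000 nM, which amounts to an expected step of no change at the digits printed from compound 3 to compound 4 (within the scatter).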

Compound 4, half-maximal effective concentration: 540 nM
Beside the measured number, compound 4's estimate is 8.9-fold (0.95 log units) above it; measured number below the stated range.
By their numbers in this assay, from the lowest: compounds 1 and 4 (each within the scatter of the next); then compounds 3 and 2 (each within the scatter of the next).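

In this assay the aromatic carbon that carries methoxy in compound 3 proves sensitive to what sits on it: trifluoromethyl there gives an 8.9-fold lower number from compound 3 to compound 4 (0.95 log units; beyond the scatter) and moves the number beyond the scatter. For the compounds shown here, the one earlier step concerned only the group on the chain carbon bound to the ring nitrogen, so this is the first sign that a group on the aromatic ring can also shift the number by a clear margin. Nothing measured here explains why this change has this effect.

The compounds shown leave open whether a nitrile, a chlorine atom or a plain hydrogen at this aromatic carbon would give a number closer to that of compound 3 or compound 4. They also leave open whether this change would have a similar effect with a cyclopropyl group on that chain carbon.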